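Free fraction in the compound 3 to compound 4 step

The source may hold more compounds than are shown below. What is called first, only, known or untested is meant among the compounds shown, and "the series" means these compounds.

Values in an ADME assay on the whole organism (serum, Rattus norvegicus) for protein binding (on this read-out higher numbers stand for a larger free fraction and lower numbers for a smaller free fraction), so far:
- compound 1 `COc1ccccc1C1C(C(=O)C(C)(C)C)=C(O)C(=O)N1c1ccc(-c2ccon2)cc1` gives 0.002
- compound 2 `Cc1noc(-c2ccc(N3C(=O)C(O)=C(C(=O)C(C)(C)C)C3c3ccccc3OCCO)cc2)n1` gives "not determined" (no result reported)
- compound 3 `COc1ccccc1C1C(C(=O)C(C)(C)C)=C(O)C(=O)N1c1ccc(-c2ccsc2)cc1` gives "not determined" (no result reported)

Compound 3 has no number in this assay, and neither does compound 2, so the series holds a single measured value. Among the compounds with values here, no step between measured compounds exists either, which leaves the size of any change untested.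

The next compound is compound 4 `C[S+]([O-])CCOc1ccccc1C1C(C(=O)C(C)(C)C)=C(O)C(=O)N1c1ccc(-c2ccsc2)cc1`. Its structural change from compound 3 is a group of 4 heavy atoms (2 carbon, 1 oxygen, 1 sulfur; no ring) in place of a hydrogen atom, on a saturated chain carbon bound to an oxygen on an aromatic ring. The new group replaces a hydrogen atom on a saturated chain carbon bound to an oxygen on an aromatic ring.

Within the data shown here, the only anchor is compound 1 at 0.002, a very small free fraction. The added group has no ring and counts one hydrogen-bond acceptor, but the data do not show what such a group does in this series. Among the measured compounds shown here, the expectation is therefore a small step toward a larger free fraction relative to that anchor, at about the edge of the usual scatter, with no step at all also plausible. For compound 4 the estimated unbound fraction is 0.004, with an expected range from 0.001 to 0.015.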

Compound 4, unbound fraction: 0.009
Beside the measured number, compound 4's estimate is 2.3-fold (0.35 log units) below it; the range from low to high includes it.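

Compound 3 has no single number in this assay and compound 4 gives 0.009, so no step can be read between them. No available evidence bears on this result. The compounds shown leave open how the group entering on the saturated chain carbon changes the free fraction in this assay.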